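Carbonyl-side aryl changes in a cytotoxicity series

The source may report more compounds than this note shows. Statements on the series, on what has been measured and on what is new or still open speak of the compounds shown alone.

Compound 1 `COc1ccc(C(=O)C2Sc3nnc(-c4cc(OC)c(OC)c(OC)c4)n3NC2c2ccco2)cc1` is the reference point. In a functional assay on MCF7 cells (Homo sapiens) for cytotoxicity, read by MTT assay, with a stated time of 48 h (a higher number here means a weaker inhibitor, a lower number a stronger inhibitor), compound 1 gives > 100000 nM, which is a limit of the assay rather than a number. Compound 2 `COc1cc(-c2nnc3n2NC(c2ccco2)C(C(=O)c2ccc(-c4ccccc4)cc2)S3)cc(OC)c1OC` differs by phenyl in place of methoxy on an aromatic carbon. In this assay compound 2 gives > 100000 nM, again a limit and not a number. Compound 3 `COc1cc(-c2nnc3n2NC(c2ccco2)C(C(=O)c2ccccc2C)S3)cc(OC)c1OC` carries 2-methylphenyl on the carbonyl carbon, and in this assay compound 3 gives 69900 nM. The measured steps read a step that the two limits leave unreadable from compound 1 to compound 2, an at least 1.4-fold lower number from compound 1 to compound 3 (0.15 log units; that floor lies within the scatter) and an at least 1.4-fold lower number from compound 2 to compound 3 (0.15 log units; that floor lies within the scatter); two of the three values sit at the limit of > 100000 nM in this assay, at which 2 of the 3 values shown sit, so compound 1 stands where the assay stops reporting numbers, and no ordering against compound 2 is possible.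

Compound 4 `COc1cc(-c2nnc3n2NC(c2ccco2)C(C(=O)c2ccc(Cl)cc2)S3)cc(OC)c1OC` is not yet measured. Its difference from compound 1: chloro in place of methoxy on an aromatic carbon. Among the measured compounds shown here, no measured step involves chloro, and the only readable steps in this assay are floors that lie within the scatter. The step for compound 4 is therefore expected at a number no higher from compound 1 to compound 4 (the limit leaves the size open), with the number likely to remain near the limit. Compound 4 is estimated at 100000 nM, between 40000 nM and 300000 nM.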

Compound 4, half-maximal inhibitory concentration: > 100000 nM
Compound 4 was reported as a limit (the forecaster's own chance of this, stated with the estimate: 60%); the middle value lies on the limit itself.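

In this assay compound 4 gives > 100000 nM, a limit of the assay and not a number. Among the compounds shown here, the only readable new step is an at least 1.4-fold higher number from compound 3 to compound 4 (0.15 log units; that floor lies within the scatter), which gives a floor and no size; the steps from compound 1 and compound 2 to compound 4 cannot be read. With chloro, the third group on this aromatic carbon, 4-chlorophenyl joins 4-methoxyphenyl and 4-phenylphenyl on the carbonyl carbon at the same limit, and compound 3 with 2-methylphenyl is the exception, the one compound that returns a number: the limit of > 100000 nM in this assay, at which 3 of the 4 values shown sit.

Still open, going by these compounds, is whether any group on this aromatic carbon, an amine or a carboxylic acid for instance, brings a number inside the range of the assay. On these data alone, the true distance of compound 1, compound 2 and compound 4 from compound 3 also remains open.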